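The source may report more compounds than this note shows. Statements on the series, on what has been measured and on what is new or still open speak of the compounds shown alone.

Measured so far in a functional assay on K562 cells (Homo sapiens) for inhibition, read by MTT assay, with a stated time of 24 h; a higher number here means a weaker inhibitor, a lower number a stronger inhibitor:
Compound 1 `CCOC1c2cc(OCc3cc(C)cc(C)c3)c(OCc3cc(C)cc(C)c3)cc2CCN1C(=O)OC(C)(C)C` gives > 20000 nM, a limit.
Compound 2 `C/C=C/C(=O)CC1c2cc(OCc3cc(C)cc(C)c3)c(OCc3cc(C)cc(C)c3)cc2CCN1C(=O)OC(C)(C)C` gives > 20000 nM, a limit.
Compound 3 `CC[C@@H]1C[C@H](O)C/C=C(/C)[C@H]2c3cc(OCc4ccccc4)c(OCc4ccccc4)cc3CCN12` gives > 20000 nM, a limit.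

Compound 2 has no number of its own in this assay, only the limit > 20000 nM. The other two readings give no number to place it against, and the whole series rests on (the limit of > 20000 nM in this assay, at which 3 of the 3 values shown sit).

Compound 4 `Cc1cc(C)cc(COc2cc3c(cc2OCc2cc(C)cc(C)c2)CN(C(=O)OC(C)(C)C)CC3)c1` has not yet been measured. The change is hydrogen in place of ((prop-1-en-1-yl)carbonyl)methyl on a saturated ring carbon, next to the ring nitrogen.

Among the compounds with values here, the one measured step at this carbon is a step that the two limits leave unreadable from compound 1 to compound 2. It has no readable size, so neither a size nor a direction can be carried over to the removal of the group. No step beyond the scatter can be expected in this assay on these data, and neither direction is favoured.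

A reading at the same limit is expected for compound 4 because compound 2 gives > 20000 nM. The expected step is a step that the limit leaves unreadable from compound 2 to compound 4, an estimate resting on limits alone. For compound 4 the estimated value is 30000 nM, with an expected range from 10000 nM to 80000 nM.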

Compound 4, half-maximal inhibitory concentration: > 20000 nM
Compound 4 ended at the assay's limit; the forecaster's own chance of this, stated with the estimate: 80%; the middle value is on the limit's open side.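

In this assay compound 4 gives > 20000 nM, a limit. No step can be read from compound 1 or compound 2 to compound 4: the limit of > 20000 nM in this assay, at which 4 of the 4 values shown sit.

The compounds shown leave open whether hydrogen, ethoxy or ((prop-1-en-1-yl)carbonyl)methyl on the saturated ring carbon makes any difference to inhibition in this assay.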